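The compounds below may be only part of what the source reports. "The series", "measured", "known", "first", "only" and "open" are said of these compounds alone.

In an ADME assay on blood (Homo sapiens) for pharmacokinetics (a lower number here means that the compound disappears faster, a higher number that the compound lasts longer), compound 1 `COC(=O)CCNC(=O)[C@@H]1O[P@@](=O)(OCOC(=O)c2ccns2)OCC1(C)C` gives only a limit, < 0.16 h. Compound 3 `COC(=O)CCNC(=O)[C@@H]1O[P@](=O)(OCOC(=O)c2ccns2)OCC1(C)C` likewise returns a limit in this assay, < 0.16 h. The step that the two limits leave unreadable from compound 1 to compound 3 cannot be sized, since the limit of < 0.16 h in this assay, at which 2 of the 3 values shown sit, covers both ends of it; what is known of the pair is the fact that compounds 1 and 3 differ only in the configuration as drawn. Compound 2 `CC(C)(C)OC(=O)CCNC(=O)[C@@H]1OP(=O)(OCOC(=O)C(C)(C)C)OCC1(C)C` gives a limit at the other end of this assay, > 1 h. That value is the limit of > 1 h in this assay, at which 1 of the 3 values shown sits. Among the measured compounds shown here, compound 2 differs from compound 1 in more than one place, so no single step is read from that pair; the two values show only that members can sit at either limit.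

Compound 4 `COC(=O)CCNC(=O)[C@@H]1O[P@@](=O)(OCOC(=O)c2ocnc2C)OCC1(C)C` carries 4-methyl-1,3-oxazol-5-yl in place of 1,2-thiazol-5-yl on a carbonyl carbon. For the measured compounds named here, no measured step bears directly on this change: the one step read between single-point neighbours is a step that the two limits leave unreadable from compound 1 to compound 3, and it is unreadable. Compound 1 stands at the lower limit of this assay, so a further step downward from it could not be seen. Compound 4 is therefore expected to stay near the same short half-life, the expected step that the limit leaves unreadable from compound 1 to compound 4 lying within the scatter. For compound 4 the expected value is 0.15 h, with a range from 0.06 h to 0.5 h, and the assay may again report only a limit.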

Compound 4, half-life: 0.52 h
The estimate for compound 4 lay 3.5-fold (0.54 log units) below the measured number; the whole stated range lies below it.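

In this assay, 4-methyl-1,3-oxazol-5-yl in place of 1,2-thiazol-5-yl on a carbonyl carbon gives an at least 3.2-fold higher number from compound 1 to compound 4 (0.51 log units; beyond the scatter) and is the first readable step in the series shown. The group on this carbonyl carbon therefore moves the half-life by more than the scatter, and compound 4 at 0.52 h in this assay is the first compound shown with a number and not a limit; the earlier single-place pair could not show this, as it changes no group: the fact that compounds 1 and 3 differ only in the configuration as drawn. Compound 1 sits at a limit, so only a lower bound on the step is known: the limit of < 0.16 h in this assay, at which 2 of the 4 values shown sit.

The change replaces the sulfur-containing ring with an oxygen-containing one and adds a methyl group in the same step, so a 1,3-oxazol-5-yl group without the methyl, or a 4-methyl-1,2-thiazol-5-yl group, would be needed to tell these two parts apart. Among the compounds shown here, also open is whether compound 4 would keep its half-life with the stereocentre at phosphorus drawn the other way, as the only pair that varies this configuration stays unreadable.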